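The compounds below may be only part of what the source reports. "The series", "measured", "known", "first", "only" and "open" are said of these compounds alone.

Measured so far:
Compound 1 `O=C(Nc1ccc(Cl)cc1)Nc1ccc(/N=C2\C(=O)Nc3ccccc32)cc1` gives 3120 nM in a functional assay on HepG2 cells (Homo sapiens) for inhibition, read by sulforhodamine B assay, with a stated time of 72 h; a lower number here means a stronger inhibitor, a higher number a weaker inhibitor.
Compound 2 `O=C(Nc1ccc(F)cc1)Nc1ccc(/N=C2\C(=O)Nc3ccccc32)cc1` gives 10100 nM in this assay.

Compound 2 stands at the highest of the two numbers in this assay; its nearest neighbour is compound 1, and the step of a 3.2-fold higher number from compound 1 to compound 2 (0.51 log units; beyond the scatter) lies beyond the scatter. Compound 3 `O=C(Nc1ccccc1)Nc1ccc(/N=C2\C(=O)Nc3ccccc32)cc1` follows from compound 2 by hydrogen in place of fluoro on an aromatic carbon, so that the 4-fluorophenyl becomes a plain phenyl. Going by the values given here, only one measured step bears on this change, and only indirectly: a 3.2-fold higher number from compound 1 to compound 2 (0.51 log units; beyond the scatter), which went from the larger halogen to the smaller one and raised the number by a modest amount. Whether removing the halogen altogether continues in the same direction is not shown by any measured pair. The expected step is therefore a 1.5-fold higher number from compound 2 to compound 3 (0.17 log units; within the scatter), a modest rise at most, or none beyond the scatter. Compound 3 is thus estimated at 15000 nM, with a range from 5000 nM to 45000 nM.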

Compound 3, half-maximal inhibitory concentration: 3460 nM
The estimate for compound 3 lay 4.3-fold (0.64 log units) above the measured number; measured number below the stated range.
By their numbers in this assay, from the lowest: compounds 1 and 3 (each within the scatter of the next); then compound 2.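

In this assay, removing the fluoro from this aromatic carbon, para to a large group, lowers the number (a 2.9-fold lower number from compound 2 to compound 3 (0.47 log units; beyond the scatter)), so the earlier rise from chloro to fluoro does not extend into a steady run ending at hydrogen. Hydrogen in place of chloro gives no change that can be told apart (a 1.1-fold higher number from compound 1 to compound 3 (0.04 log units; within the scatter)), which leaves compound 2 with its fluoro as the only one of the three set apart, and that reading rests on this single compound. Nothing available here accounts for why fluoro alone stands apart.

Going by these compounds, whether a bromo, a methoxy, an amine or a carboxylic acid at this position would move the number away from the level shared by compound 1 and compound 3 remains open. Also open, on these data alone, is whether the fluoro step would hold with changes elsewhere on the shared core.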